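The source may hold more compounds than are shown below. What is called first, only, known or untested is meant among the compounds shown, and "the series" means these compounds.

Of the compounds shown here, three sharing one core have been measured in an ADME assay on the whole organism (plasma, Rattus norvegicus) for protein binding, using cassette dosing, at a dose of 1 mg/kg (a lower number here means a smaller unbound share, a higher number a larger unbound share of the compound), all carrying the 2-carboxypropyl chain. Compound 1 `CC(C)Oc1ccc(/N=c2\[nH]c(=O)n(C[C@@H](C)C(=O)O)c(=O)n2Cc2ccc(Cl)cc2)cc1Cl` gives 0.002, the lowest of the three numbers, while compound 3 `C[C@@H](Cn1c(=O)[nH]/c(=N\c2ccc(Oc3nccs3)cc2)n(Cc2ccc(Cl)cc2)c1=O)C(=O)O` gives 0.006 and compound 2 `Cc1cc(/N=c2\[nH]c(=O)n(C[C@H](C)C(=O)O)c(=O)n2Cc2ccc(Cl)cc2)ccc1OC(C)C` gives 0.02, both beyond the scatter from compound 1. Compound 4 `CC(C)Oc1ccc(/N=c2\[nH]c(=O)n(C[C@@H](O)CO)c(=O)n2Cc2ccc(Cl)cc2)cc1Cl` keeps the rest of compound 1 and differs in one place: 1,2-dihydroxyethyl in place of 1-carboxyethyl on a saturated chain carbon bound to an aromatic nitrogen, with 1,2-dihydroxyethyl in place of 1-carboxyethyl on a saturated chain carbon bound to an aromatic nitrogen. For the measured compounds named here, no measured pair shows this change, so the expectation is a judgement. An upward move in this assay beyond the scatter is expected, with an estimated 5.0-fold higher number from compound 1 to compound 4 (0.70 log units; beyond the scatter). For compound 4 the expected unbound fraction is 0.01, with an estimated range of 0.003 to 0.04.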

Compound 4, unbound fraction: 0.001
Estimate against measurement, compound 4: 10-fold (1.00 log units) above; measured number below the stated range.
By their numbers in this assay, from the lowest: compounds 4 and 1 (each within the scatter of the next); then compound 3; then compound 2.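

Exchanging 1-carboxyethyl for 1,2-dihydroxyethyl on a saturated chain carbon bound to an aromatic nitrogen gives, in this assay, a 2.0-fold lower number from compound 1 to compound 4 (0.30 log units; within the scatter). For the compounds shown here, the earlier compounds all carried the 2-carboxypropyl chain, so only this pair shows that, on the core of compound 1, the unbound fraction stays at the same level with 2,3-dihydroxypropyl in its place.

Going by these compounds, whether an amine or a longer chain at this place would also leave the number unmoved stays open, as does whether the same exchange behaves alike on compound 2 and compound 3. Nothing measured here offers a reason for this result.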